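The source may report more compounds than this note shows. Statements on the series, on what has been measured and on what is new or still open speak of the compounds shown alone.

Compound 1 `O=C1C(Nc2ccc(F)cc2)=CC(=O)c2ncccc21` and compound 2 `O=C1C(Nc2ccc(F)cc2F)=CC(=O)c2ncccc21` share one core, while compound 3 `O=C1C=C(Nc2ccccc2)C(=O)c2cnccc21` and compound 4 `O=C1C=C(Nc2cccc(F)c2)C(=O)c2cnccc21` share another; the difference between the two cores is not broken down here. In a functional assay on the whole organism (aorta) with Rattus norvegicus as the target (a lower number here means a smaller maximal response, a higher number a larger maximal response), compound 1 gives 79% and compound 2 gives 94%. The change fluoro in place of hydrogen on an aromatic carbon made a step of a number 15 percentage points higher from compound 1 to compound 2 (beyond the scatter). In this assay compound 3 gives 93%. The change fluoro in place of hydrogen on an aromatic carbon is the same kind of change, yet the place differs: in compound 2 the fluoro sits ortho to a large group and meta to a fluoro group, in compound 4 only meta to a large group. Since compound 3 already reaches 93% and the earlier step came from a different place, a smaller step is expected, a number 4 percentage points higher from compound 3 to compound 4 (within the scatter). Compound 4 is expected to give 97% in this assay, between 85% and 108%.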

Compound 4, largest response reached (Emax), in percent of the reference or control that the assay uses: 89%
For compound 4 the middle estimate is 8 percentage points above the measured one; the range from low to high includes it.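

In this assay, the fluoro change did not carry over as one fixed step from one core to the other: the same change on two cores in this assay, a number 15 percentage points higher (beyond the scatter) from compound 1 to compound 2 and a number 4 percentage points lower (within the scatter) from compound 3 to compound 4, 19 percentage points apart, beyond the scatter of two such steps. On the core of compound 3, the step reads a number 4 percentage points lower from compound 3 to compound 4 (within the scatter), so this fluoro gives no shift that stands out from the usual scatter. This does not show that the core alone sets the size of the step, since the fluoro also stands in a different place in the two pairs, and these two steps give no reason for the gap.

The compounds shown leave open whether fluoro in one and the same place would give matching steps on both cores. They also leave open how a chloro group, a methoxy group or an amine on this ring would behave.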